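A few compounds are considered here, and "the series" means these few. Any claim that something is new, unique, unknown or untested is made for them only; others in the source may bear on it.

Of the compounds shown here, three have so far been tested in an ADME assay on A549 cells (Homo sapiens) for cytotoxicity, read by CellTiter-Glo; a lower number here means that less compound is tolerated, a higher number that more compound is tolerated. Compound 1 `Cc1c(Cc2ccccc2)c(=O)oc2cc(OCC(O)CNCc3ccccc3)ccc12` reaches only the limit of this assay, > 100000 nM. Compound 2 `Cc1c(Cc2ccc(OC(F)(F)F)cc2)c(=O)oc2cc(OC[C@@H](O)CN3CCC(C(N)=O)CC3)ccc12` gives 64900 nM. Compound 3 `NC(=O)C1CCN(CC(O)COc2ccc3c(C4CC4)c(Cc4ccccc4)c(=O)oc3c2)CC1` likewise stops at the limit, > 100000 nM. Compound 3 therefore stands at the limit of > 100000 nM in this assay, at which 2 of the 3 values shown sit, so no number is known for it, only a bound. Compound 4 `NC(=O)C1CCN(CC(O)COc2ccc3c(-c4ccccc4)c(Cc4ccccc4)c(=O)oc3c2)CC1` is the next compound to be measured; it differs from compound 3 by phenyl in place of cyclopropyl on an aromatic carbon. Among the measured compounds shown here, no measured pair differing in one place exists here, so the size of such a step is not known from these data; a change within the scatter, or none, is what is expected. Compound 4 is expected to give 80000 nM, with a range from 30000 nM to 200000 nM. The expected step of an at least 1.2-fold lower number from compound 3 to compound 4 (0.09 log units; that floor lies within the scatter) is estimated to lie within the scatter.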

Compound 4, half-maximal cytotoxic concentration: 25200 nM
The estimate for compound 4 lay 3.2-fold (0.50 log units) above the measured number; the measured number lies below the stated range.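

The group on the aromatic carbon opposite the ring oxygen matters for tolerance: in this assay phenyl in place of cyclopropyl gives an at least 3.9-fold lower number from compound 3 to compound 4 (0.59 log units; beyond the scatter) here. Among the compounds shown here, this is the first single-place comparison in the set, and it shows less compound tolerated with phenyl at this position. The true size of the step stays unknown because compound 3 sits at a limit: the limit of > 100000 nM in this assay, at which 2 of the 4 values shown sit.

As far as these compounds go, whether an amine or a pyridine ring at this position would be tolerated like phenyl or like cyclopropyl remains open. So does whether the same change would have a similar effect with a different side chain.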